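Series notes: chain-end nitrile exchanged for a carboxylic acid

The compounds below may be only part of what the source reports. "The series", "measured", "known", "first", "only" and "open" are said of these compounds alone.

In an assay on isolated protein for binding affinity to leukotriene B4 receptor 1 (Homo sapiens), tested at 1 uM (on this read-out lower numbers stand for less inhibition and higher numbers for more inhibition at the one concentration tested (going by the name of the read-out)), compound 3 `CCc1cc(C(C)=O)c(O)cc1OCCCCCC(C)(C)C#N` gives 53%. On the three numbers recorded this is the lowest, but the gap to the nearest, compound 1 `CCc1cc(C(C)=O)c(O)cc1OCCCCC#N` with 57%, is within the scatter, whereas compound 2 `CCc1cc(C(C)=O)c(O)cc1OCCCCCCC#N` with 73% lies clearly apart, as a number 20 percentage points lower from compound 2 to compound 3 (beyond the scatter) shows. The remaining measured steps are a number 16 percentage points higher from compound 1 to compound 2 (beyond the scatter) and a number 4 percentage points lower from compound 1 to compound 3 (within the scatter).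

Compound 4 `CCc1cc(C(C)=O)c(O)cc1OCCCC(C)(C)C(=O)O` is not yet measured in this assay. Its change relative to compound 3 is 1-carboxy-1-methylethyl in place of 3-cyano-3-methylbutyl on a saturated chain carbon, three bonds along the chain from an oxygen on an aromatic ring. Every measured step exchanges one nitrile-bearing group for another nitrile-bearing group on the same chain carbon; none removes the nitrile, none introduces a carboxylic acid, and none shortens the chain in this manner. Among the compounds with values here, no measured step therefore bears directly on this change. The measured steps only set a scale: within the series, altering the chain beyond the aromatic oxygen has moved this assay by at most a modest amount, and compound 1 and compound 3 sit together.

Absent a precedent, the expected step of a number 5 percentage points higher from compound 3 to compound 4 (within the scatter) is taken as none beyond the scatter, with wide uncertainty. For compound 4 the estimate in this assay is 58%, within a range from 28% to 88%.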

Compound 4, a percentage reported as inhibition, at one concentration (the size of the read-out at that concentration, not a potency): 43%
For compound 4 the middle estimate is 15 percentage points above the measured one; low and high end bracket the measured number.
By their numbers in this assay, from the lowest: compounds 4, 3 and 1 (each within the scatter of the next, the first and the last beyond it); then compound 2.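

Within the data shown here, the first exchange of the nitrile for a carboxylic acid shows that a chain end without a nitrile still gives a reading in this assay, with compound 4 at 43%, and that a number 10 percentage points lower from compound 3 to compound 4 (within the scatter) leaves it inside the scatter of the gem-dimethyl nitrile. Against the two nitriles without those methyl groups the new group falls short, with a number 14 percentage points lower from compound 1 to compound 4 (beyond the scatter) and a number 30 percentage points lower from compound 2 to compound 4 (beyond the scatter), the second being the largest step seen so far in this series. Nothing on hand accounts for these steps.

Each of these steps changes the chain end and the chain length together, so the share belonging to the carboxylic acid and the share belonging to the shorter chain remain unresolved, and the comparison with compound 3 alone cannot settle it. Still open, going by these compounds, are how the 1-carboxy-1-methylethyl group would read on a longer chain, such as that of compound 2, and whether an amide at the end of the chain of compound 4 would read closer to the nitriles or to the carboxylic acid.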